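Compound 2 to compound 4: one phenyl group exchanged

A few compounds are considered here, and "the series" means these few. Any claim that something is new, unique, unknown or untested is made for them only; others in the source may bear on it.

- compound 1 `Cc1ccccc1C1CC(c2ccc(OCc3ccccc3)cc2)=NN1c1ccc(S(N)(=O)=O)cc1`: 100000 nM
- compound 2 `NS(=O)(=O)c1ccc(N2N=C(c3ccc(Oc4ccccc4)cc3)CC2c2cccc(F)c2)cc1`: 28000 nM
- compound 3 `NS(=O)(=O)c1ccc(N2N=C(c3ccc(OCc4ccccc4)cc3)CC2c2cccc(F)c2)cc1`: 90000 nM
- compound 4 `NS(=O)(=O)c1ccc(N2N=C(c3ccc(Oc4ccccc4)cc3)CC2c2ccc(Cl)cc2)cc1`: not yet measured

In an ADME assay on Vero 76 cells (Chlorocebus sabaeus) for cytotoxicity, read by MTT assay, with a stated time of 96 h (on this read-out higher numbers stand for lower toxicity in this test and lower numbers for higher toxicity in this test), compound 2 gives 28000 nM, the lowest of the three numbers, which makes it the most toxic of the three in this test. Its nearest neighbour is a 3.2-fold higher number from compound 2 to compound 3 (0.51 log units; beyond the scatter), but that step concerns benzyl in place of phenyl on an oxygen on an aromatic ring, a different place in the molecule.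

Compound 4 differs from compound 2 at one place: 4-chlorophenyl in place of 3-fluorophenyl on a saturated ring carbon. The closest evidence is an exchange at that same carbon, 3-fluorophenyl in place of 2-methylphenyl, which gave a 1.1-fold lower number from compound 1 to compound 3 (0.05 log units; within the scatter). Within the data shown here, this is only one exchange, and it was seen with benzyl rather than phenyl on the oxygen. Among the measured compounds shown here, no measured compound carries 4-chlorophenyl. On this evidence, no step beyond the scatter is expected in this assay.

The expected step, an estimate only, is no change at the digits printed from compound 2 to compound 4 (within the scatter). Compound 4 is therefore estimated at 28000 nM, with an expected range of 12000 nM to 65000 nM.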

Compound 4, half-maximal cytotoxic concentration: 88000 nM
Beside the measured number, compound 4's estimate is 3.1-fold (0.50 log units) below it; the whole stated range lies below it.
By their numbers in this assay, from the lowest: compound 2; then compounds 4, 3 and 1 (each within the scatter of the next).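

In this assay, among these compounds, the saturated ring carbon next to the ring nitrogen now shows a step beyond the scatter: 4-chlorophenyl in place of 3-fluorophenyl gives a 3.1-fold higher number from compound 2 to compound 4 (0.50 log units; beyond the scatter), while the only earlier exchange at this carbon, 3-fluorophenyl in place of 2-methylphenyl, gave a 1.1-fold lower number from compound 1 to compound 3 (0.05 log units; within the scatter), which lies within the scatter. Among the compounds shown here, a change at this carbon can therefore move the number, though the step is modest and has been seen only with phenyl on the oxygen, and here a higher number means lower toxicity in this test. Compound 2 also now stands apart through two different single changes, since benzyl in place of phenyl on the oxygen gave a 3.2-fold higher number from compound 2 to compound 3 (0.51 log units; beyond the scatter), but nothing measured here explains the rise seen with 4-chlorophenyl.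

This exchange alters both the halogen and its place on the ring, so the compounds shown cannot separate those two changes. As far as these compounds go, it also remains open how a plain phenyl or a methoxyphenyl group at this carbon would read, and whether 4-chlorophenyl would give a similar step with benzyl on the oxygen.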